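Working notes on the shared core: chain variation at nitrogen

The source may hold more compounds than are shown below. What is called first, only, known or untested is meant among the compounds shown, and "the series" means these compounds.

Three compounds with the shared core have numbers in a functional assay on A549 cells (Homo sapiens) for cytotoxicity, read by MTT assay, with a stated time of 72 h (on this read-out higher numbers stand for weaker inhibition and lower numbers for stronger inhibition), so far. Compound 1 `O=C1c2c[n+]([O-])c3ccccc3c2C(=O)c2c1c1ccccc1n2Cc1cn(C[C@H](O)CO)nn1` gives 1030 nM and stands highest of the three. Compound 2 `CCCCN1CCN(CCCCn2c3c(c4ccccc42)C(=O)c2c[n+]([O-])c4ccccc4c2C3=O)CC1` gives 550 nM, which lies within the scatter of compound 1. Compound 3 `CC1(C)OC[C@H](Cn2cc(Cn3c4c(c5ccccc53)C(=O)c3c[n+]([O-])c5ccccc5c3C4=O)nn2)O1` gives 340 nM, and the step of a 3.0-fold lower number from compound 1 to compound 3 (0.48 log units; beyond the scatter) is the only one that passes the scatter.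

Compound 4 `CN(C)CCCCn1c2c(c3ccccc31)C(=O)c1c[n+]([O-])c3ccccc3c1C2=O` is not yet measured. Against compound 1 it differs as follows: 3-(dimethylamino)propyl in place of 1-(2,3-dihydroxypropyl)-1H-1,2,3-triazol-4-yl on a saturated chain carbon bound to an aromatic nitrogen. Going by the values given here, only one measured step concerns this place on the chain, and it is a 3.0-fold lower number from compound 1 to compound 3 (0.48 log units; beyond the scatter), which already shows that the part of compound 1 that leaves can be changed without the number rising. The change to compound 4 goes further than that step, so it is read only as a pointer. Compound 2 carries a chain at the same nitrogen ending in a saturated amine, and compound 2 gives 550 nM. Set beside it, compound 1 with its 1030 nM shows no gap beyond the scatter.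

The expectation for compound 4 is therefore a modest fall, a 2.3-fold lower number from compound 1 to compound 4 (0.36 log units; beyond the scatter), estimated at 450 nM with a range from 150 nM to 1300 nM.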

Compound 4, half-maximal inhibitory concentration: 310 nM
For compound 4 the middle estimate is 1.5-fold (0.16 log units) above the measured one; low and high end bracket the measured number.
By their numbers in this assay, from the lowest: compounds 4, 3, 2 and 1 (each within the scatter of the next, the first and the last beyond it).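

In this assay, 3-(dimethylamino)propyl in place of 1-(2,3-dihydroxypropyl)-1H-1,2,3-triazol-4-yl on a saturated chain carbon bound to an aromatic nitrogen lowers the number beyond the scatter (a 3.3-fold lower number from compound 1 to compound 4 (0.52 log units; beyond the scatter)). The earlier step kept the five-membered aromatic ring and altered only its 1,2-dihydroxyethyl end, whereas this change removes the ring, both hydrogen-bond donors and the defined stereocentre, so the lower number at this place does not depend on any of them in compound 4. The chain end also now has a second comparison: dimethylamino in place of 4-butylpiperazin-1-yl on a saturated chain carbon, four bonds along the chain from an aromatic nitrogen, leaves the number within the scatter (a 1.8-fold lower number from compound 2 to compound 4 (0.25 log units; within the scatter)), so these two amine ends are not distinguished by this assay.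

Still open, on these data alone, is whether the number holds with a shorter or longer chain carrying the dimethylamino group, or with a carboxylic acid or a primary amine at the chain end. Nothing at hand accounts for the differences seen between these compounds.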